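This account rests on a few compounds, and the source may have more. Where it says the series, first, only, none or still open, it means among the compounds named here.

Measured so far:
- compound 1 `Cc1cc(CO)cc(C)c1Oc1cc(Nc2ccc(C#N)cc2)c(N)cc1CO`: 15900 nM
- compound 2 `Cc1cc(CCC#N)cc(C)c1Oc1cc(Nc2ccc(C#N)cc2)c(N)cc1C(N)=O`: > 9400 nM

Among the compounds with values here, in an ADME assay on TZM cells (Homo sapiens) for cytotoxicity, read by XTT assay, with a stated time of 4 days (on this read-out lower numbers stand for higher toxicity in this test and higher numbers for lower toxicity in this test), compound 1 gives 15900 nM, the only plain number among the two values shown. For compound 2 the value > 9400 nM is a limit of this assay, not a number, as noted in the limit of > 9400 nM in this assay, at which 1 of the 2 values shown sits. Compound 3 `Cc1cc(/C=C/C#N)cc(C)c1Oc1cc(Nc2ccc(C#N)cc2)c(N)cc1CO` has not yet been tested. It differs from compound 1 by 2-cyanoethenyl in place of hydroxymethyl on an aromatic carbon. Within the data shown here, no step between two measured compounds is available to calibrate this change, so only a modest shift in this assay is expected, toward slightly higher toxicity, possibly not beyond the scatter. Compound 3 is therefore estimated at 10000 nM, within 4000 nM to 30000 nM, a step of a 1.6-fold lower number from compound 1 to compound 3 (0.20 log units; within the scatter).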

Compound 3, half-maximal cytotoxic concentration: 16300 nM
The estimate for compound 3 lay 1.6-fold (0.21 log units) below the measured number; low and high end bracket the measured number.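

Replacing hydroxymethyl with 2-cyanoethenyl, on the aromatic carbon para to a large group, gives a 1.0-fold higher number from compound 1 to compound 3 (0.01 log units; within the scatter) in this assay for this pair. Within the data shown here, this is the first step read at this position, and it shows no readable difference, even though the entering group has more heavy atoms and no hydrogen-bond donor.

Going by these compounds, whether an amine, a carboxylic acid or a longer chain at this position would read the same remains open. Compound 2 has a limit and not a number, so it provides no further step: the limit of > 9400 nM in this assay, at which 1 of the 3 values shown sits.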